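This account rests on a few compounds, and the source may have more. Where it says the series, first, only, none or still open, it means among the compounds named here.

Working notes on the series.

Three compounds share one core. Compound 1 `CCCCOc1ccc(Nc2nc3nonc3nc2O)cc1` gives 3700 nM in an assay on mitochondria from L6 cells (Rattus norvegicus) for activation, with a stated time of 90 min; a higher number here means that more compound is needed for the effect, a lower number that less compound is needed. Compound 2 `Oc1nc2nonc2nc1Nc1ccc(OCC(F)(F)F)cc1` gives 42300 nM in this assay, and compound 3 `Oc1nc2nonc2nc1Nc1ccc(S(F)(F)(F)(F)F)cc1` gives 3900 nM in this assay. On these numbers compound 3 sits second highest of the three: its gap to compound 1 is small, a 1.1-fold higher number from compound 1 to compound 3 (0.02 log units; within the scatter), and stays within the scatter, while its gap to compound 2 is large and beyond the scatter, an 11-fold lower number from compound 2 to compound 3 (1.04 log units; beyond the scatter).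

The next compound, compound 4 `CCc1ccc(Nc2nc3nonc3nc2O)cc1`, differs from compound 3 in one place: a group of 2 heavy atoms (2 carbon; no ring) in place of a group of 6 heavy atoms (5 fluorine, 1 sulfur; no ring), on an aromatic carbon.

Within the data shown here, two measured steps bear on this change. The step of a 1.1-fold higher number from compound 1 to compound 3 (0.02 log units; within the scatter) shows that exchanging the group of five heavy atoms in compound 1 for the fluorine-sulfur group of compound 3 moved the number hardly at all, whereas an 11-fold higher number from compound 1 to compound 2 (1.06 log units; beyond the scatter) shows a large rise once trifluoromethyl replaced propyl on the chain. Ethyl is a short carbon-only group, closer in kind to the chain of compound 1 than to the fluorinated groups, so for compound 4 the expected step in this assay is a small one, a 1.5-fold higher number from compound 3 to compound 4 (0.19 log units; within the scatter), somewhat toward a higher number but not clearly beyond the scatter.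

Compound 4 is thus estimated at 6000 nM in this assay, with a range from 2000 nM to 20000 nM.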

Compound 4, half-maximal effective concentration: 10700 nM
The estimate for compound 4 lay 1.8-fold (0.25 log units) below the measured number; measured number inside the range.
By their numbers in this assay, from the lowest: compounds 1 and 3 (each within the scatter of the next); then compound 4; then compound 2.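

Working notes, continued. In this assay, among these compounds, ethyl, the only carbon-only group seen so far on this aromatic carbon, does not sit level with either of the two groups that match each other, the butoxy of compound 1 and the group of 5 fluorine and 1 sulfur of compound 3 (a 2.9-fold higher number from compound 1 to compound 4 (0.46 log units; beyond the scatter) and a 2.7-fold higher number from compound 3 to compound 4 (0.44 log units; beyond the scatter)). It also stays clear of the trifluoroethoxy compound (a 4.0-fold lower number from compound 2 to compound 4 (0.60 log units; beyond the scatter)), so the four compounds now fall on three separate levels: compounds 1 and 3 together, then compound 4, then compound 2. A carbon chain at this place therefore does not by itself give the level of compound 1, since the ethyl and butoxy compounds differ by a modest step, and the match between compound 1 and compound 3 is not shared by every group without fluorine.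

No measurement at hand accounts for any of these steps. Open, going by these compounds, is where a propyl or butyl chain without the oxygen, a short methoxy, or an amine or carboxylic acid on the same aromatic carbon would fall, and so whether the oxygen or the chain length of compound 1 goes with its lower number.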